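Extending the oxime ether chain with a hydroxyl terminus

The source may report more compounds than this note shows. Statements on the series, on what has been measured and on what is new or still open speak of the compounds shown alone.

Measured compounds:
- compound 1, `CCO/N=C/c1c(N)ncnc1Oc1ccc2[nH]c(C)cc2c1F`: 27 nM
- compound 2, `CCCO/N=C/c1c(N)ncnc1Oc1ccc2[nH]c(C)cc2c1F`: 28 nM
- compound 3, `CO/N=C/c1c(N)ncnc1Oc1ccc2cccnc2c1`: 886 nM

In a functional assay on A-375 cells (Homo sapiens) for antiproliferative activity (on this read-out higher numbers stand for weaker inhibition and lower numbers for stronger inhibition), compound 1 has the lowest number of the three, with compound 2 a near match (a 1.0-fold higher number from compound 1 to compound 2 (0.02 log units; within the scatter)) and compound 3 giving a far higher number. Compound 4, `Cc1cc2c(F)c(Oc3ncnc(N)c3/C=N/OCCCO)ccc2[nH]1`, has not yet been measured. It differs from compound 1 by hydroxymethyl in place of hydrogen on a saturated chain carbon, two bonds along the chain from an oxygen. Going by the values given here, the only step that bears on this change is the one from compound 1 to compound 2, which lengthened the same chain at the same carbon and stayed within the scatter. Compound 4 is therefore expected to sit close to compound 1, with a step of about a 1.3-fold higher number from compound 1 to compound 4 (0.11 log units; within the scatter). The estimate for compound 4 is 35 nM, within 14 nM to 90 nM.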

Compound 4, half-maximal inhibitory concentration: 336 nM
The estimate for compound 4 lay 9.6-fold (0.98 log units) below the measured number; the whole stated range lies below it.
By their numbers in this assay, from the lowest: compounds 1 and 2 (each within the scatter of the next); then compound 4; then compound 3.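

In this assay, the hydroxy proved decisive where added chain length alone had not: the change from ethoxy to 3-hydroxypropoxy gives a 12-fold higher number from compound 1 to compound 4 (1.09 log units; beyond the scatter) and adding only the hydroxy to the propyl chain gives a 12-fold higher number from compound 2 to compound 4 (1.08 log units; beyond the scatter). The two steps are of like size, so the loss in compound 4 goes with the hydroxy and not with the extra carbon. Nothing available explains this loss. On these data alone, whether a methoxy or an amine in place of that hydroxy would bring the same loss remains open, as does the effect of a longer chain carrying the hydroxy.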